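The source may report more compounds than this note shows. Statements on the series, on what has been measured and on what is new or still open speak of the compounds shown alone.

Measured in a physicochemical assay for solubility, read by HPLC, with a stated time of 24 h; a lower number here means a less soluble compound, a higher number a more soluble compound:
- compound 1 `CN(CCC#N)C[C@H]1CN(c2ccc(-n3cc(-c4ccccn4)cn3)c(F)c2)C(=O)O1`: 64500 nM
- compound 2 `O=C(OC[C@H]1CN(c2ccc(-n3cc(-c4ccccn4)cn3)c(F)c2)C(=O)O1)c1ccccc1`: <= 65400 nM

The entry for compound 2 is a limit and not a number, namely (the limit of <= 65400 nM in this assay, at which 1 of the 2 values shown sits). Compound 3 `CN(C)S(=O)(=O)NC[C@H]1CN(c2ccc(-n3cc(-c4ccccn4)cn3)c(F)c2)C(=O)O1` has not been measured, and it differs from compound 2 in one place: (dimethylsulfamoyl)amino in place of benzoyloxy on a saturated chain carbon bound to a saturated ring carbon. For the measured compounds named here, the only measured step, a step that the limit leaves unreadable from compound 1 to compound 2, has no readable size, so it offers no size or direction to carry over. No step beyond the scatter is therefore expected, and the expected change is a step that the limit leaves unreadable from compound 2 to compound 3. Compound 3 is expected to give 40000 nM in this assay, with an estimated range of 10000 nM to 65000 nM.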

Compound 3, solubility: 472000 nM
Estimate against measurement, compound 3: 12-fold (1.07 log units) below; the measured number lies above the stated range.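

This position can move the read-out well beyond the scatter, which the earlier pair could not show. In this assay, (dimethylsulfamoyl)amino in place of (2-cyanoethyl)(methyl)amino gives a 7.3-fold higher number from compound 1 to compound 3 (0.86 log units; beyond the scatter), and in place of benzoyloxy it gives an at least 7.2-fold higher number from compound 2 to compound 3 (0.85 log units; beyond the scatter). The second step starts from a limit and not a number: the limit of <= 65400 nM in this assay, at which 1 of the 3 values shown sits.

Which part of the (dimethylsulfamoyl)amino group goes with the higher number remains open. A plain primary amine or a methanesulfonylamino group on the same saturated chain carbon would help separate those parts.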